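The source may report more compounds than this note shows. Statements on the series, on what has been measured and on what is new or still open speak of the compounds shown alone.

Measured compounds:
- Compound 1, `O=C(C1CCN(C(=O)C(F)(F)F)CC1)N1N=CCC1c1ccccc1`: 0.483 h
- Compound 2, `O=C(C1CCCCC1)N1N=CCC1c1ccccc1`: 0.0833 h
- Compound 3, `CC(C)(C)C(=O)N1N=CCC1c1cccc(Cl)c1`: 0.05 h

These three compounds share a core in which a carbonyl is attached to a ring nitrogen, and they were tested in an ADME assay on microsomes (Rattus norvegicus) for metabolic stability; a lower number here means that the compound disappears faster, a higher number that the compound lasts longer. Compound 1 gives the highest of the three numbers; its nearest neighbour is compound 2, whose number is well below it, beyond the usual scatter, and compound 3 stands further down still. None of the three pairs differs in only one place, so no single structural step can be read from them; the two lower numbers simply belong to compounds carrying a cyclohexyl or a tert-butyl on the carbonyl instead of the piperidine of compound 1.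

Compound 4, `O=C(c1ccccc1)N1CCC(C(=O)N2N=CCC2c2ccccc2)CC1`, has not yet been measured. It differs from compound 1 in one place: phenyl in place of trifluoromethyl on a carbonyl carbon. Among the measured compounds shown here, since no measured pair shows this kind of exchange, the size of the step is uncertain. A modest move downward in this assay is expected, though one that may stay within the usual scatter, given that compound 1 already holds the top value. The step from compound 1 to compound 4 is therefore estimated as a 1.6-fold lower number from compound 1 to compound 4 (0.21 log units; within the scatter). For compound 4 the expected value is 0.3 h, with a range from 0.1 h to 0.9 h.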

Compound 4, half-life: 0.0833 h
Beside the measured number, compound 4's estimate is 3.6-fold (0.56 log units) above it; measured number outside the range, below it.
By their numbers in this assay, from the lowest: compounds 3, 2 and 4 (each within the scatter of the next); then compound 1.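

In this assay, among the compounds shown here, the exchange of trifluoromethyl for phenyl on a carbonyl carbon whose other neighbour is an amide-type nitrogen in a ring gives a 5.8-fold lower number from compound 1 to compound 4 (0.76 log units; beyond the scatter) and is the first change in this set that can be read in a single place. The result shows that this position is not indifferent to the group on that carbonyl: with the rest of the structure unchanged, this one exchange moves the half-life beyond the usual scatter. The data show only the size and direction of this step, and nothing at hand explains why the compound lasts a shorter time.

The compounds shown leave open whether a smaller group such as methyl, or a ring such as cyclopropyl or pyridine, on this carbonyl would give a number closer to that of compound 1 or to that of compound 4. From the compounds shown here alone, it also remains open whether the same exchange would give a step of similar size if the unsubstituted phenyl on the shared core carried a chlorine.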